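Swapping vinyl for naphthalen-1-yl on the shared core

The compounds below may be only part of what the source reports. "The series", "measured", "known", "first", "only" and "open" are said of these compounds alone.

In a functional assay on MCF7 cells (Homo sapiens) for inhibition, read by MTT assay, with a stated time of 72 h (on this read-out higher numbers stand for weaker inhibition and lower numbers for stronger inhibition), compound 1 `Cc1cc(Nc2cc(-c3ccccc3)[nH]n2)n2nc(SCc3ccc(F)cc3)nc2n1` gives 4020 nM. Compound 2 `C=CCSc1nc2nc(C)cc(Nc3cc(-c4ccccc4)[nH]n3)n2n1` gives > 50000 nM, which is a limit of the assay and not a number. Compound 2 thus stands at the limit of > 50000 nM in this assay, at which 1 of the 2 values shown sits.

Compound 3 `Cc1cc(Nc2cc(-c3ccccc3)[nH]n2)n2nc(SCc3cccc4ccccc34)nc2n1` differs from compound 2 by naphthalen-1-yl in place of vinyl on a saturated chain carbon bound to a sulfur. Among the measured compounds shown here, one measured step bears on this change: an at least 12-fold higher number from compound 1 to compound 2 (1.09 log units; beyond the scatter), a large step beyond the scatter in which vinyl replaced 4-fluorophenyl at the same place. Compound 3 puts an aromatic group back there, so a large step toward lower numbers is expected in this assay, landing near compound 1 at 4020 nM. The expected step is an at least 10-fold lower number from compound 2 to compound 3 (1.00 log units; beyond the scatter). Compound 3 is estimated at 5000 nM, with an expected range of 1500 nM to 20000 nM.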

Compound 3, half-maximal inhibitory concentration: 7560 nM
Beside the measured number, compound 3's estimate is 1.5-fold (0.18 log units) below it; measured number inside the range.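

In this assay, naphthalen-1-yl in place of vinyl on a saturated chain carbon bound to a sulfur gives an at least 6.6-fold lower number from compound 2 to compound 3 (0.82 log units; beyond the scatter), so the low numbers at this position are not tied to 4-fluorophenyl alone. The two aromatic groups cannot be told apart here, with a 1.9-fold higher number from compound 1 to compound 3 (0.27 log units; within the scatter), even though naphthalen-1-yl brings two six-membered aromatic rings of carbon only. The value of compound 2 is a limit of the assay and not a number: the limit of > 50000 nM in this assay, at which 1 of the 3 values shown sits.

The compounds shown leave open whether an aromatic ring is what matters here, or whether a saturated ring such as cyclohexyl, or a longer chain, on the same carbon would serve as well. They also do not tell what an amine or a carboxylic acid at this place would do.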